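Adding a pyridine ring to a potent inhibitor

A few compounds are considered here, and "the series" means these few. Any claim that something is new, unique, unknown or untested is made for them only; others in the source may bear on it.

Compound 1 `Cc1c(COc2cccc(OCC3CCOCC3)c2)[nH]c2ccc(C(=O)O)cc2c1=O`: 400 nM
Compound 2 `Cc1c(COc2cccc(OCC3CCOCC3)c2)[nH]c2ccccc2c1=O`: 8.9 nM

Both numbers come from a functional assay on HUVEC cells (Homo sapiens) for inhibition, using NADPH, with a stated time of 2 h (a lower number here means a stronger inhibitor, a higher number a weaker inhibitor), and are half-maximal inhibitory concentrations, so the smaller number marks the stronger inhibitor. Among the measured compounds shown here, compound 2 at 8.9 nM holds the lower of the two numbers, and compound 1 at 400 nM is its only neighbour.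

The next compound, compound 3 `Cc1c(COc2cccc(OCC3CCOCC3)c2)[nH]c2ccc(-c3cccnc3)cc2c1=O`, has not yet been measured. It is compound 2 with pyridin-3-yl in place of hydrogen on an aromatic carbon and it carries this ring on the same carbon that holds the carboxy group in compound 1.

For the measured compounds named here, only one measured step bears on this change, the large one of a 45-fold lower number from compound 1 to compound 2 (1.65 log units; beyond the scatter) in which hydrogen replaces carboxy. It shows that a group on this carbon can cost a great deal of potency, yet it concerns a different group, so it offers only a rough guide. A smaller loss seems the fair expectation, and an estimated step of a 2.8-fold higher number from compound 2 to compound 3 (0.45 log units; beyond the scatter) is expected in this assay as a move toward weaker inhibition. For compound 3 the expected value is 25 nM with an estimated range from 5 nM to 120 nM until a measurement is available.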

Compound 3, half-maximal inhibitory concentration: > 10000 nM
Compound 3: only a limit was reported; the forecaster's own chance of this, stated with the estimate: 2%; middle value at least 400-fold (2.60 log units) from the limit.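

In this assay, compound 3 carries a limit and not a number: the limit of > 10000 nM in this assay, at which 1 of the 3 values shown sits.

Even read as a limit, placing pyridin-3-yl on this aromatic carbon gives an at least 1100-fold higher number from compound 2 to compound 3 (3.05 log units; beyond the scatter), so this one added ring takes the compound from a measured value to a limit. Among the compounds shown here, the comparison with the carboxy compound gives an at least 25-fold higher number from compound 1 to compound 3 (1.39 log units; beyond the scatter), which shows that pyridin-3-yl is clearly worse at this carbon than carboxy, the only other group tested there. Until now, the cost of a group at this carbon rested on carboxy alone; with compound 1 and compound 3 both far weaker than compound 2, it now holds for two quite different groups, and hydrogen remains the best of the three.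

How much weaker compound 3 really is stays open, and the compounds shown give no reason for the loss. Also unknown is whether a small group such as methyl, fluorine or an amine would be tolerated on this carbon, or whether any group placed there lowers potency.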